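Chloro to amino on the fused benzo ring

A few compounds are considered here, and "the series" means these few. Any claim that something is new, unique, unknown or untested is made for them only; others in the source may bear on it.

Measured so far:
- compound 1, `Nc1nn(C(=O)Nc2ccc(Cc3ccccc3)cc2)c2ccccc12`: 13500 nM
- compound 2, `Nc1nn(C(=O)Nc2ccc(Cc3ccccc3)cc2)c2ccc(Cl)cc12`: 5880 nM

In a functional assay on BT-549 cells (Homo sapiens) for antiproliferative activity, read by sulforhodamine B assay, with a stated time of 48 h (a lower number here means a stronger inhibitor of growth, a higher number a weaker inhibitor of growth), compound 1 gives 13500 nM, while compound 2 gives 5880 nM. The one step measured, a 2.3-fold lower number from compound 1 to compound 2 (0.36 log units; beyond the scatter), is modest but clears the scatter; compound 2 therefore holds the lower of the two numbers shown, and the only neighbour it can be set against is compound 1.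

Compound 3, `Nc1ccc2c(c1)c(N)nn2C(=O)Nc1ccc(Cc2ccccc2)cc1`, keeps the shared core and the benzyl-bearing aryl urea of compound 2 and changes a single ring substituent: amino in place of chloro on an aromatic carbon. Within the data shown here, no measured pair speaks to an amino at this position, so the only guide is the chloro-for-hydrogen step, a 2.3-fold lower number from compound 1 to compound 2 (0.36 log units; beyond the scatter), which says a small halogen there helps a little. From the compounds shown here alone, an amino is not a halogen, and whether the gain with chloro carries over is unknown; the cautious reading is that compound 3 lands somewhere between the two measured values, with no confident call on direction beyond the scatter.

Estimate for compound 3 in this assay: 9000 nM, within 3000 nM to 25000 nM. This estimate implies a step of a 1.5-fold higher number from compound 2 to compound 3 (0.18 log units; within the scatter), expected to be small.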

Compound 3, concentration for 50% growth inhibition: 14600 nM
For compound 3 the middle estimate is 1.6-fold (0.21 log units) below the measured one; measured number inside the range.
By their numbers in this assay, from the lowest: compound 2; then compounds 1 and 3 (each within the scatter of the next).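

In this assay amino in place of chloro gives a 2.5-fold higher number from compound 2 to compound 3 (0.39 log units; beyond the scatter) and so gives up the modest gain that chloro brought, showing that the earlier gain does not extend to any substituent placed on this aromatic carbon. Amino in place of hydrogen gives a 1.1-fold higher number from compound 1 to compound 3 (0.03 log units; within the scatter) and cannot be told apart from hydrogen here, so of the two groups now read at this position, only chloro separates from hydrogen beyond the scatter, and even that step is modest. No measured evidence bears on why chloro and amino differ at this position.

The three compounds leave open whether the gain is particular to chloro or would also appear with fluoro, bromo, methyl, methoxy or nitrile on the same aromatic carbon, and a series of such groups would show whether any step here can grow beyond modest. From the compounds shown here alone, all three compounds also share the benzyl-bearing aryl urea, so whether the chloro-to-amino step keeps its size with a different group on that part of the molecule remains unknown.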